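Fluorine on the sulfonyl ring of a sulfonamide

The source may report more compounds than this note shows. Statements on the series, on what has been measured and on what is new or still open speak of the compounds shown alone.

Of the compounds shown here, three share a trimethoxyphenyl sulfonamide core and have been tested in a functional assay on PC-3 cells (Homo sapiens) for inhibition, read by MTT assay, with a stated time of 48 h; a higher number here means a weaker inhibitor, a lower number a stronger inhibitor. Compound 2 `COc1cc(N(Cc2ccccc2)S(=O)(=O)c2ccc(C)cc2)cc(OC)c1OC` gives 7810 nM. Compound 1 `COc1cc(N(Cc2ccc(F)cc2)S(=O)(=O)c2ccc(C)cc2)cc(OC)c1OC` carries one change, (fluoro in place of hydrogen on an aromatic carbon), and gives 20700 nM; the step is a 2.7-fold higher number from compound 2 to compound 1 (0.42 log units; beyond the scatter). Compound 3 `COc1cc(N(Cc2nc3ccccc3[nH]2)S(=O)(=O)c2ccccc2)cc(OC)c1OC` differs from compound 2 in more than one place, and the difference between the two cores is not broken down here; in this assay compound 3 gives 25500 nM, which sits within the scatter of compound 1 and beyond it from compound 2.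

Compound 4 `COc1cc(N(Cc2nc3ccccc3[nH]2)S(=O)(=O)c2ccc(F)cc2)cc(OC)c1OC` is not yet measured. It differs from compound 3 by fluoro in place of hydrogen on an aromatic carbon. This is the same change that leads from compound 2 to compound 1, and the place is described in the same words, on an aromatic carbon of a six-membered aromatic ring of carbon only, para to a large group; read one bond further out it turns phenylsulfonyl into (4-fluorophenyl)sulfonyl rather than benzyl into 4-fluorobenzyl, so the ring that takes the fluorine is a different one. Going by the values given here, with only that one earlier example to lean on, a weaker inhibitor is expected for compound 4, with a step of about a 2.0-fold higher number from compound 3 to compound 4 (0.29 log units; within the scatter), because the change gave a 2.7-fold higher number from compound 2 to compound 1 (0.42 log units; beyond the scatter). Compound 4 is therefore estimated at 50000 nM, between 20000 nM and 150000 nM.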

Compound 4, half-maximal inhibitory concentration: 7990 nM
The estimate for compound 4 lay 6.3-fold (0.80 log units) above the measured number, and the stated range ends above it.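

In this assay, fluoro in place of hydrogen on an aromatic carbon gave a 3.2-fold lower number from compound 3 to compound 4 (0.50 log units; beyond the scatter), so on this core the fluorine goes with a stronger inhibitor. The change that goes by the same name went the opposite way on the other core, so its direction did not carry from one core to the other in these two pairs: the same change on two cores in this assay, a 2.7-fold higher number (0.42 log units; beyond the scatter) from compound 2 to compound 1 and a 3.2-fold lower number (0.50 log units; beyond the scatter) from compound 3 to compound 4, 8.5-fold (0.93 log units) apart, beyond the scatter of two such steps This does not show why the two steps part, since the pairs differ both in their cores and in the ring that takes the fluorine, benzyl becoming 4-fluorobenzyl in one and phenylsulfonyl becoming (4-fluorophenyl)sulfonyl in the other, and two pairs cannot separate those differences or set a rule for the series.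

The compounds shown leave open what the same change does on a single core when only the ring that takes the fluorine is varied, which would be the direct way to pull those two differences apart. They also leave open whether chloro, a nitrile or an amine in that same place would move the number in the same direction as fluoro.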